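A few compounds are considered here, and "the series" means these few. Any claim that something is new, unique, unknown or untested is made for them only; others in the source may bear on it.

Among the measured compounds shown here, compound 3 `CCCCc1ccc(S(=O)(=O)N2CCN(C(=O)Oc3ccc([N+](=O)[O-])cc3)CC2)cc1` gives the lowest number of the three compounds measured so far: in an assay on isolated protein for inhibition of Fatty-acid amide hydrolase 1 (Homo sapiens), read by fluorescence (on this read-out lower numbers stand for stronger inhibition and higher numbers for weaker inhibition), compound 3 gives 179 nM. Compound 1 `O=C(Oc1ccc([N+](=O)[O-])cc1)N1CCN(S(=O)(=O)c2ccc(Oc3ccccc3)cc2)CC1` stands nearest to it, as in this assay compound 1 gives 322 nM, and the step of a 1.8-fold lower number from compound 1 to compound 3 (0.26 log units; within the scatter) stays within the scatter. Compound 2 `O=C(Oc1ccc([N+](=O)[O-])cc1)N1CCN(S(=O)(=O)c2ccc(-c3ccc(Cl)c(Cl)c3)cc2)CC1` stands furthest away, as in this assay compound 2 gives 382 nM, and the step of a 2.1-fold lower number from compound 2 to compound 3 (0.33 log units; beyond the scatter) lies beyond the scatter, though only modestly.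

Compound 4 `O=C(Oc1ccc([N+](=O)[O-])cc1)N1CCN(S(=O)(=O)c2ccc(Oc3ccc(Cl)c(Cl)c3)cc2)CC1` differs from compound 3 by one change, (3,4-dichlorophenoxy in place of butyl on an aromatic carbon). For the measured compounds named here, two measured steps bear on this. The step of a 1.8-fold lower number from compound 1 to compound 3 (0.26 log units; within the scatter) shows that exchanging phenoxy and butyl moves the number only within the scatter. The step of a 2.1-fold lower number from compound 2 to compound 3 (0.33 log units; beyond the scatter) shows that exchanging butyl for 3,4-dichlorophenyl moves it modestly beyond the scatter, toward weaker inhibition. Compound 4 carries both a phenoxy linkage and the two chlorines, so a modestly higher number is expected for compound 4, about a 2.0-fold higher number from compound 3 to compound 4 (0.29 log units; within the scatter). The estimate for compound 4 in this assay is 350 nM, with a range from 150 nM to 800 nM.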

Compound 4, half-maximal inhibitory concentration: 317 nM
For compound 4 the middle estimate is 1.1-fold (0.04 log units) above the measured one, and the stated range covers the measured number.
By their numbers in this assay, from the lowest: compounds 3, 4, 1 and 2 (each within the scatter of the next, the first and the last beyond it).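

In this assay, adding the two chlorines to the phenoxy ring moves the number only within the scatter (a 1.0-fold lower number from compound 1 to compound 4 (0.01 log units; within the scatter)), so on this ring they make no readable difference. Exchanging 3,4-dichlorophenyl for 3,4-dichlorophenoxy, which adds one oxygen, also stays within the scatter (a 1.2-fold lower number from compound 2 to compound 4 (0.08 log units; within the scatter)), and so does exchanging butyl for 3,4-dichlorophenoxy (a 1.8-fold higher number from compound 3 to compound 4 (0.25 log units; within the scatter)). Compound 4 therefore lies within the scatter of all three earlier compounds, even though the two ends of the series remain modestly apart (a 2.1-fold lower number from compound 2 to compound 3 (0.33 log units; beyond the scatter)), so this aromatic carbon holds a butyl chain and both ring-bearing groups with little separation in the numbers.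

Going by these compounds, whether an amine, a carboxylic acid or a longer chain here would move the number further remains open. Nothing measured here offers a reason for these small differences.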